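The compounds below may be only part of what the source reports. "The series", "measured", "known", "first", "only" and "open" are said of these compounds alone.

Compound 1 `O=C(CCN1CCN(c2ccc(Cl)cc2)CC1)c1ccc(Br)cc1`: 52100 nM
Compound 2 `O=C(CCN1CCN(c2ccc(Cl)cc2)CC1)c1ccc(F)c(F)c1`: 86200 nM

In an ADME assay on Vero cells (Chlorocebus sabaeus) for cytotoxicity, read by resazurin assay, with a stated time of 72 h (on this read-out higher numbers stand for weaker inhibition and lower numbers for stronger inhibition), compound 1 gives 52100 nM, and compound 2 gives 86200 nM. Among the measured compounds shown here, these two numbers lie within the scatter of each other, so compound 1 cannot be separated from its only measured neighbour.

Compound 3 `O=C(CCN1CCN(c2ccc(Cl)cc2)CC1)c1ccc(C(F)(F)F)cc1` has not yet been measured. It differs from compound 1 by trifluoromethyl in place of bromo on an aromatic carbon, with trifluoromethyl in place of bromo on an aromatic carbon, para to a large group.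

For the measured compounds named here, one measured step bears on this change, since it also alters the aromatic group on the carbonyl carbon. That step, with 3,4-difluorophenyl in place of 4-bromophenyl, is a 1.7-fold higher number from compound 1 to compound 2 (0.22 log units; within the scatter). Going by the values given here, with only this small step from compound 1 as a guide, no shift beyond the scatter is expected in this assay. The expected step is a 1.2-fold higher number from compound 1 to compound 3 (0.06 log units; within the scatter). For compound 3 the estimated value is 60000 nM, with an expected range from 28000 nM to 125000 nM.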

Compound 3, half-maximal inhibitory concentration: 54200 nM
Compound 3: middle estimate off by 1.1-fold (0.04 log units), on the high side, within the range that was stated.
By their numbers in this assay, from the lowest: compounds 1, 3 and 2 (each within the scatter of the next).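

In this assay, trifluoromethyl in place of bromo on an aromatic carbon, para to a large group, gives a 1.0-fold higher number from compound 1 to compound 3 (0.02 log units; within the scatter). This is the first step shown that alters only the single group at this position, and although four heavy atoms enter where one leaves, the two compounds cannot be separated in this assay, just as the earlier step to the 3,4-difluorophenyl compound could not be. No measurement shown here explains this result.

The compounds shown leave open whether an amine or a carboxylic acid at this position would move the number beyond the scatter. They also leave open whether a longer chain between the carbonyl and the shared core would do so.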